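Pyrrole in Place of Dimethylamino: Cytotoxicity Expectation

This account rests on a few compounds, and the source may have more. Where it says the series, first, only, none or still open, it means among the compounds named here.

Compound 1 `CN(C)c1ccc(NCc2cncn2Cc2ccc(-c3ccccc3)cc2)cc1-c1ccccc1`: > 1000 nM
Compound 2 `COC(=O)c1ccc(NCc2cncn2Cc2ccccc2F)cc1-c1ccccc1`: "not determined" (no result reported)
Compound 3 `c1ccc(-c2ccc(Cn3cncc3CNc3ccc(-c4ccc[nH]4)c(-c4ccccc4)c3)cc2)cc1`: not yet measured

In a toxicity assay on NIH3T3 cells (Mus musculus) for cytotoxicity, read by resazurin assay (on this read-out lower numbers stand for an effect already at smaller amounts and higher numbers for an effect only at larger amounts of compound), compound 1 gives > 1000 nM, which is a limit of the assay rather than a number, as the limit of > 1000 nM in this assay, at which 1 of the 2 values shown sits, shows. Compound 2 has "not determined" (no result reported) in this assay. Compound 3 differs from compound 1 by 1H-pyrrol-2-yl in place of dimethylamino on an aromatic carbon. Within the data shown here, no measured pair of compounds shows how such a change plays out, so the expectation rests on compound 1 alone. The step expected in this assay is a step that the limit leaves unreadable from compound 1 to compound 3, none beyond the usual scatter. Compound 3 is expected to give 2000 nM, within a range from 700 nM to 6000 nM, and quite possibly again only as a limit.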

Compound 3, half-maximal effective concentration: > 10000 nM
Compound 3: no number, only a limit; the forecaster's own chance of this, stated with the estimate: 60%; middle value at least 5.0-fold (0.69 log units) from the limit.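

In this assay compound 1 and compound 3 each give only a limit rather than a number, and the step between them cannot be read. On these data alone, whether 1H-pyrrol-2-yl in place of dimethylamino shifts this read-out at all, and how far, remains open.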